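A nitrophenyl ether in place of a trifluoromethylphenyl ketone

The source may hold more compounds than are shown below. What is called first, only, known or untested is meant among the compounds shown, and "the series" means these compounds.

In a functional assay on U-251 cells (Homo sapiens) for antiproliferative activity, read by MTT assay, with a stated time of 24 h (a lower number here means a stronger inhibitor, a higher number a weaker inhibitor), compound 3 `COc1cc(OC)c(-c2coc3cc(OCC(=O)c4cccc(C(F)(F)F)c4)ccc3c2=O)cc1OC` gives > 10000 nM, which is a limit of the assay rather than a number. Compound 1 `C=CCOc1ccc2c(=O)c(-c3cc(OC)c(OC)cc3OC)coc2c1` gives 5900 nM in this assay, and compound 2 `COc1cc(OC)c(-c2coc3cc(OCc4ccccc4)ccc3c2=O)cc1OC` gives 6750 nM. Compound 4 `COc1cc(OC)c(-c2coc3cc(OCc4ccc([N+](=O)[O-])cc4)ccc3c2=O)cc1OC` differs from compound 3 by 4-nitrophenyl in place of (3-(trifluoromethyl)phenyl)carbonyl on a saturated chain carbon bound to an oxygen on an aromatic ring. The measured steps that bear on this change are an at least 1.4-fold higher number from compound 2 to compound 3 (0.17 log units; that floor lies within the scatter) and an at least 1.6-fold higher number from compound 1 to compound 3 (0.22 log units; that floor lies within the scatter); both are floors that lie within the scatter, and the change to compound 4 runs close to the reverse of the step from compound 2. Compound 4 is therefore expected, because of an at least 1.4-fold higher number from compound 2 to compound 3 (0.17 log units; that floor lies within the scatter), to take a step of an at least 1.4-fold lower number from compound 3 to compound 4 (0.15 log units; that floor lies within the scatter) toward a lower number. The estimate for compound 4 is 7000 nM, between 3000 nM and 15000 nM.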

Compound 4, half-maximal inhibitory concentration: 9400 nM
Beside the measured number, compound 4's estimate is 1.3-fold (0.13 log units) below it; the range from low to high includes it.
By their numbers in this assay, from the lowest: compounds 1, 2 and 4 (each within the scatter of the next). At a limit, above all of these: compound 3.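

In this assay, nitro in place of hydrogen on an aromatic carbon brings a 1.4-fold higher number from compound 2 to compound 4 (0.14 log units; within the scatter), and 4-nitrophenyl in place of vinyl brings a 1.6-fold higher number from compound 1 to compound 4 (0.20 log units; within the scatter). On this saturated chain carbon, vinyl, phenyl and 4-nitrophenyl therefore remain within the scatter of one another. The step of an at least 1.0-fold lower number from compound 3 to compound 4 (0.02 log units; that floor lies within the scatter) cannot settle how 4-nitrophenyl compares with (3-(trifluoromethyl)phenyl)carbonyl, since compound 3 gives only a limit of the assay: the limit of > 10000 nM in this assay, at which 1 of the 4 values shown sits.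

Going by these compounds, whether an amine or a carboxylic acid on this chain carbon would move the number beyond the scatter remains open.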